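The source may hold more compounds than are shown below. What is called first, only, known or untested is meant among the compounds shown, and "the series" means these compounds.

Measured set:
Compound 1 `COc1ccc(-c2nc(C)oc2C(=O)N2CCN(c3cccc(Cl)c3)CC2)cc1` gives "not active" (no number reported) in a functional assay on HL-60 cells (Homo sapiens) for inhibition, read by MTT assay, with a stated time of 72 h; on this read-out lower numbers stand for stronger inhibition and higher numbers for weaker inhibition.
Compound 2 `CCc1nc(-c2ccc(OC)cc2)c(C(=O)N2CCN(c3cccc(Cl)c3)CC2)o1` gives > 1000 nM in this assay, and this is a limit of the assay, not a number.
Compound 3 `COc1cccc(N2CCN(C(=O)c3oc(C(F)(F)F)nc3-c3cccc(F)c3)CC2)c1` gives "not active" (no number reported) in this assay.

Compound 1 stands without a single number in this assay; of the three values shown, one sits at the limit of > 1000 nM in this assay, at which 1 of the 3 values shown sits, and the other two, that of compound 1 among them, carry no number at all. Within the data shown here, no two measured compounds differ in one place, so no measured step can be read. Compound 4 `COc1ccc(-c2nc(C)oc2C(=O)N2CCN(c3cccc(Cl)c3)CC2)cc1O` differs from compound 1 by hydroxy in place of hydrogen on an aromatic carbon. Among the measured compounds shown here, with no measured step to lean on, no shift beyond the scatter in this assay is expected in either direction from compound 1. Compound 4 is therefore expected to give about 5000 nM in this assay, within 1000 nM to 30000 nM, most likely again reported as a limit only.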

Compound 4, half-maximal inhibitory concentration: "not active" (no number reported)
The entry for compound 4 holds no number, and the estimate cannot be compared.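

In this assay compound 1 gives "not active" (no number reported) and compound 4 gives "not active" (no number reported), so no step can be read between them. The compounds shown leave open whether hydroxy in place of hydrogen has any effect, and whether this series gives a single number at all in this assay, since the only other entry is a limit: the limit of > 1000 nM in this assay, at which 1 of the 4 values shown sits.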